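Trading a Chlorobenzyl Amide for a Fluorophenylethyl Amide

The compounds below may be only part of what the source reports. "The series", "measured", "known", "first", "only" and "open" are said of these compounds alone.

Compound 1, with the structure `N[C@H]1CC[C@H](Nc2c(C(=O)NCc3ccc(Cl)cc3)nc(Br)c3cccnc23)CC1`, is the reference point here. In a functional assay on MDA-MB-435 cells (Homo sapiens) for cytotoxicity, read by MTT assay, with a stated time of 72 h (on this read-out higher numbers stand for weaker inhibition and lower numbers for stronger inhibition), compound 1 gives 1000 nM, the lowest of the two numbers reported, so on this read-out it is the stronger of the two measured compounds. Compound 3, with the structure `N[C@H]1CC[C@H](Nc2c(C(=O)NCc3ccc(Oc4ccccc4)cc3)nc(Br)c3cccnc23)CC1`, differs from it only at the aromatic ring of the amide side chain, and in this assay compound 3 gives 4000 nM; the change gives a 4.0-fold higher number from compound 1 to compound 3 (0.60 log units; beyond the scatter). Compound 2, with the structure `CS(=O)(=O)Oc1c(C(=O)NCc2ccc(F)cc2)nc(Br)c2cccnc12`, carries a different group on the shared core, and in this assay compound 2 gives only a limit, > 20000 nM, at which one of the three reported values sits (the limit of > 20000 nM in this assay, at which 1 of the 3 values shown sits).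

Compound 4, with the structure `C[C@H](NC(=O)c1nc(Br)c2cccnc2c1N[C@H]1CC[C@H](N)CC1)c1ccc(F)cc1`, is not yet measured. It differs from compound 1 as follows: 1-(4-fluorophenyl)ethyl in place of 4-chlorobenzyl on an amide-type nitrogen. Within the data shown here, no measured pair covers this exact exchange; the only step at that part of the molecule, from compound 1 to compound 3, was modest and went toward weaker inhibition, while the limit for compound 2 cannot be set beside compound 4 because its core differs. The expected step from compound 1 to compound 4 in this assay is therefore small, a 1.5-fold higher number from compound 1 to compound 4 (0.18 log units; within the scatter), with no confident direction. Compound 4 is estimated at 1500 nM, within a range of 500 nM to 5000 nM.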

Compound 4, half-maximal inhibitory concentration: > 10000 nM
Compound 4 ended at the assay's limit; the forecaster's own chance of this, stated with the estimate: 10%; middle value at least 6.6-fold (0.82 log units) from the limit.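

Compound 4 gives only a limit of the assay, not a number: the limit of > 10000 nM in this assay, at which 1 of the 4 values shown sits. Even so, swapping 4-chlorobenzyl for 1-(4-fluorophenyl)ethyl on an amide-type nitrogen can be read as a step, an at least 10-fold higher number from compound 1 to compound 4 (1.00 log units; beyond the scatter), and it shows that this side chain can matter more than the one earlier step there suggested, a 4.0-fold higher number from compound 1 to compound 3 (0.60 log units; beyond the scatter). Both changes go toward weaker inhibition, and the exchange that keeps a single aromatic ring and adds one defined stereocentre costs more than the exchange of chloro for phenoxy.

The entering group differs in two ways at once, with fluorine in place of chlorine and a new branched carbon that carries the stereocentre, and the compounds shown cannot tell which of these accounts for the loss. Going by these compounds, a 1-(4-chlorophenyl)ethyl group, or a 4-fluorobenzyl group on the same core as compound 1, would separate the two changes, and how the mirror-image form of the 1-(4-fluorophenyl)ethyl group behaves also remains open.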